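A few compounds are considered here, and "the series" means these few. Any claim that something is new, unique, unknown or untested is made for them only; others in the source may bear on it.

Of the compounds shown here, two sharing one core have so far been measured in an assay on DDT1 cells (Cricetulus griseus) for binding affinity to adenosine receptor A1 (Homo sapiens), read by radioligand binding; on this read-out lower numbers stand for stronger inhibition and higher numbers for weaker inhibition. Compound 1 `CCCC/N=C(\S)OC[C@H]1OC(n2cnc3c(NC4CCOC4)ncnc32)[C@H](O)[C@@H]1O` carries a butyl group on the double-bonded nitrogen, and in this assay compound 1 gives 157 nM. Compound 2 `O[C@@H]1[C@@H](CO/C(S)=N/C2CCCC2)OC(n2cnc3c(NC4CCOC4)ncnc32)[C@@H]1O` carries a cyclopentyl group there instead, and in this assay compound 2 gives 72 nM. That exchange brought a 2.2-fold lower number from compound 1 to compound 2 (0.34 log units; beyond the scatter). Going by the values given here, compound 2 therefore holds the lowest of the two numbers, with compound 1 as its only neighbour.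

Compound 3 `O=C(NC1CCCCC1)OC[C@H]1OC(n2cnc3c(NC4CCOC4)ncnc32)[C@H](O)[C@@H]1O` has not yet been measured. It differs from compound 2 in that (a group of 9 heavy atoms (7 carbon, 1 nitrogen, 1 oxygen; one six-membered non-aromatic ring of carbon only) in place of a group of 8 heavy atoms (6 carbon, 1 nitrogen, 1 sulfur; one five-membered non-aromatic ring of carbon only), on an oxygen on a saturated carbon). Two things move at once: the five-membered ring becomes a six-membered one, and the sulfur gives way to an oxygen, leaving a cyclohexylcarbamoyl group. Among the compounds with values here, only the step from compound 1 to compound 2 bears on this, and only in part: it showed that a ring in place of a chain at this end gave a modestly lower number. Nothing measured shows what trading the sulfur for oxygen does. For compound 3 a small downward step or none beyond the scatter is expected, a 1.2-fold lower number from compound 2 to compound 3 (0.08 log units; within the scatter). Compound 3 is thus estimated at 60 nM, within 20 nM to 200 nM.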

Compound 3, inhibition constant: 584 nM
Estimate against measurement, compound 3: 9.7-fold (0.99 log units) below; the measured number lies above the stated range.
By their numbers in this assay, from the lowest: compound 2; then compound 1; then compound 3.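

Going by these compounds alone, the end group on this oxygen matters more than the first pair of compounds suggested: in this assay, the change to cyclohexylcarbamoyl brought an 8.1-fold higher number from compound 2 to compound 3 (0.91 log units; beyond the scatter), a larger move than the one seen when cyclopentyl replaced butyl. A ring at this end does not by itself go with a lower number, as the change from the butyl group to cyclohexylcarbamoyl gave a 3.7-fold higher number from compound 1 to compound 3 (0.57 log units; beyond the scatter), so compound 2 fits the earlier ring-for-chain reading and compound 3 goes against it. No measurement at hand gives a reason for this rise.

The compounds shown leave open which part of the change carries the step, the larger ring or the oxygen that stands where the sulfur stood, since both moved together in compound 3. A cyclopentylcarbamoyl group would hold the five-membered ring of compound 2 while making only the exchange of sulfur for oxygen, and a cyclohexyl ring on the sulfur-bearing group of compound 2 would test the ring size alone.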